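A few compounds are considered here, and "the series" means these few. Any claim that something is new, unique, unknown or untested is made for them only; others in the source may bear on it.

Measured so far:
Compound 1 `COc1ccc2oc(-c3cn4nc(OC)sc4n3)cc2c1`: 30%
Compound 2 `c1ccc(Sc2nn3cc(-c4cc5ccccc5o4)nc3s2)cc1`: "not determined" (no result reported)
Compound 3 `COc1cc(OCc2cccc(COc3ccccc3)c2)c2cc(-c3cn4nc(OC)sc4n3)oc2c1`: 86%

In an ADME assay on microsomes from liver (Homo sapiens) for metabolic stability, with a stated time of 10 min (on this read-out higher numbers stand for a more stable compound and lower numbers for a less stable compound), compound 3 holds the higher of the two reported numbers; compound 1 sits far beneath it, a gap beyond the usual scatter, while compound 2 carries no reported number at all. Compound 4 `COc1cc(OCc2cccc(Oc3ccccc3)c2)c2cc(-c3cn4nc(OC)sc4n3)oc2c1` differs from compound 3 in one place: phenoxy in place of phenoxymethyl on an aromatic carbon. Within the data shown here, no two measured compounds differ by exactly this change, so its size cannot be read from the data. Among the measured compounds shown here, since the change touches only one side group of compound 3, a step no larger than the scatter, or a slight fall, is expected. For compound 4 the estimate in this assay is 78%, within a range from 55% to 95%, meaning an expected step of a number 8 percentage points lower from compound 3 to compound 4 (within the scatter).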

Compound 4, percent of the compound remaining: 86%
Estimate against measurement, compound 4: 8 percentage points below, and the stated range covers the measured number.
By their numbers in this assay, from the lowest: compound 1; then compounds 3 and 4 (each within the scatter of the next).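

In this assay, putting phenoxy in place of phenoxymethyl on this aromatic carbon gives no change at the digits printed from compound 3 to compound 4 (within the scatter). Among these compounds, this is the first comparison here between compounds that differ in only one place, and it shows that this side group can be one heavy atom smaller without a detectable shift in the percent remaining. No evidence here bears on why the number holds. Still open, going by these compounds, is whether a very different group at this position, such as an amine or a carboxylic acid, would keep the read-out in this range.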